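Swapping a pyridin-2-yl for cyclohexyl on a weakly cytotoxic scaffold

The compounds below may be only part of what the source reports. "The series", "measured", "known", "first", "only" and "open" are said of these compounds alone.

The account starts from compound 1 `O[C@@H](c1ccccc1)[C@H]1CO[C@H](c2ccccc2)[C@@H](C/C=C/c2ccccn2)C1`. In a functional assay on HeLa cells (Homo sapiens) for cytotoxicity, read by WST assay, with a stated time of 48 h (on this read-out lower numbers stand for stronger inhibition and higher numbers for weaker inhibition), compound 1 gives 33800 nM. Two other compounds from the same series have been measured. Compound 3 `COc1ccc(/C=C/C[C@@H]2C[C@@H]([C@@H](O)c3ccc(OC)c(OC)c3)CO[C@H]2c2ccccc2)cc1OC` gives 16100 nM in this assay, a number lower than that of compound 1 by a margin beyond the usual scatter, so compound 1 stands as the highest of the two numbers shown. Compound 2 `COc1ccc(/C=C/C[C@@H]2C[C@@H]([C@@H](OC)c3ccc(OC)c(OC)c3)CO[C@H]2c2ccc(OC)c(OC)c2)cc1OC` is a different case: in this assay it reaches only a limit, > 100000 nM, and no number is reported for it. Thus, of the three values shown, one sits at the limit of > 100000 nM in this assay, at which 1 of the 3 values shown sits.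

Compound 4 `O[C@@H](c1ccccc1)[C@H]1CO[C@H](c2ccccc2)[C@@H](C/C=C/C2CCCCC2)C1` has not yet been measured in this assay. It differs from compound 1 in a single place: cyclohexyl in place of pyridin-2-yl on a double-bonded chain carbon bound to a double-bonded chain carbon. Among the compounds with values here, no step between two measured compounds mirrors this change, so the expectation rests only on the weak activity seen for compound 1 and compound 3 and on the limit reached by compound 2. The estimated step of a 1.0-fold higher number from compound 1 to compound 4 (0.02 log units; within the scatter) is expected to be small, in either direction, and not clearly beyond the scatter. Compound 4 is therefore expected to give about 35000 nM in this assay, within a range from 12000 nM to 100000 nM.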

Compound 4, half-maximal inhibitory concentration: 6440 nM
The estimate for compound 4 lay 5.4-fold (0.74 log units) above the measured number; measured number outside the range, below it.
By their numbers in this assay, from the lowest: compound 4; then compound 3; then compound 1. At a limit, above all of these: compound 2.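

In this assay, within the data shown here, cyclohexyl in place of pyridin-2-yl on a double-bonded chain carbon bound to a double-bonded chain carbon gives a 5.2-fold lower number from compound 1 to compound 4 (0.72 log units; beyond the scatter), and this is the first step that can be read, since none of the earlier compounds differed in one place only. It shows that this position is not indifferent to the ring it carries, even though the heavy-atom count of the group stays the same. The lower number goes with a six-membered non-aromatic ring of carbon only, in place of a six-membered aromatic ring with one hetero atom and one hydrogen-bond acceptor.

This single step changes the ring nitrogen and the aromatic character together, so the compounds shown leave open which of the two goes with the lower number, and what a plain phenyl, a piperidin-4-yl ring or a longer alkyl chain would give at this place. Nothing among the data shown bears on why the step occurs.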